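Swapping a methyl for a hydroxycyclohexyl on the urea nitrogen

The compounds below may be only part of what the source reports. "The series", "measured", "known", "first", "only" and "open" are said of these compounds alone.

Of the compounds shown here, three built on one shared core have been tested in a functional assay on the whole organism for inhibition, with Rattus norvegicus as the target, at a dose of 30 mg/kg by the oral route; on this read-out higher numbers stand for more inhibition at the one dose given (going by the name of the read-out) and lower numbers for less inhibition. Compound 1 `CN(C(=O)NCCCOc1ccc2nc(O)ccc2c1)C1CCCCC1` gives 15% and stands at the top of the three numbers. Compound 3 `CN(C(=O)NCCCOc1ccc2nc(O)ccc2c1)[C@@H]1CCCC[C@H]1O` gives 10%; the change a number 5 percentage points lower from compound 1 to compound 3 (within the scatter) stays within the usual scatter of the measurement. Among the compounds with values here, compound 2 `O=C(NCCCOc1ccc2nc(O)ccc2c1)N(C1CC1)[C@@H]1CCCCC[C@H]1O` gives 0%, a number beyond the scatter from that of compound 1, though compound 2 differs from the others in more than one place, so no single step can be drawn to it.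

Compound 4 `O=C(NCCCOc1ccc2nc(O)ccc2c1)N(C1CCCCC1)[C@H]1CCCC[C@@H]1O` is the next one to be measured. It differs from compound 1 in one place: 2-hydroxycyclohexyl in place of methyl on an amide-type nitrogen. Within the data shown here, the only measured step that bears on this is the one in which a hydroxy entered on a saturated ring carbon, a number 5 percentage points lower from compound 1 to compound 3 (within the scatter), within the scatter. Among the measured compounds shown here, no measured step shows a 2-hydroxycyclohexyl replacing a methyl on this nitrogen, so the expectation rests on that single small step and carries real uncertainty. The expected change is a number 7 percentage points lower from compound 1 to compound 4 (within the scatter), essentially nothing beyond the scatter. Compound 4 is therefore estimated to give 8%, with a range from 0% to 25%.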

Compound 4, a percentage reported as inhibition, in the whole organism at one dose (the size of the read-out at that dose, not a potency): 18%
Beside the measured number, compound 4's estimate is 10 percentage points below it; measured number inside the range.
By their numbers in this assay, from the lowest: compounds 2, 3, 1 and 4 (each within the scatter of the next, the first and the last beyond it).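

On the amide-type nitrogen whose other neighbours are the carbonyl carbon and a saturated ring carbon, methyl can give way to the far larger 2-hydroxycyclohexyl, with its six-membered ring, hydroxy and two defined stereocentres. In this assay, this exchange gives a number 3 percentage points higher from compound 1 to compound 4 (within the scatter), so even this large change in size and make-up at the position does not move the read-out beyond the usual scatter. The earlier single step, a number 5 percentage points lower from compound 1 to compound 3 (within the scatter), showed only a hydroxy entering on a saturated ring already present, and no information accompanies either result that could explain why the read-out holds steady.

From the compounds shown here alone, what the hydroxy contributes on the entering ring remains open, since a plain cyclohexyl on this nitrogen would be needed to separate the effect of the ring from that of the hydroxy. Also open, going by these compounds, are how an amine or a carboxylic acid in place of that hydroxy would read, and whether the opposite arrangement at the two stereocentres would give a different number at this one dose.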